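Methyl Next to the Ring Nitrogen: A Modest Change Expected

A few compounds are considered here, and "the series" means these few. Any claim that something is new, unique, unknown or untested is made for them only; others in the source may bear on it.

Measured compounds:
compound 1 `N/C(=N\NC(=S)N1CCCCCC1)c1ccccn1` — 6000 nM
compound 2 `Cc1cccc(/C(N)=N/NC(=S)N2CCOCC2)n1` — 2200 nM
compound 3 `Cc1ccnc(/C(N)=N/NC(=S)N2CCCCCC2)c1` — 7000 nM

In a functional assay on HeLa cells (Homo sapiens) for cytotoxicity, read by MTT assay, with a stated time of 72 h (a higher number here means a weaker inhibitor, a lower number a stronger inhibitor), compound 1 gives 6000 nM, the second highest of the three numbers. Its nearest neighbour is compound 3, and the step of a 1.2-fold higher number from compound 1 to compound 3 (0.07 log units; within the scatter) lies within the scatter. Among the compounds with values here, compound 2 stands furthest away: in this assay compound 2 gives 2200 nM, a lower number than compound 1 by a gap beyond the scatter, but compound 2 differs from compound 1 in two places, so no single step connects them.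

Compound 4 `Cc1cccc(/C(N)=N/NC(=S)N2CCCCCC2)n1` is not yet measured. It arises from compound 1 by methyl in place of hydrogen on an aromatic carbon. Within the data shown here, the only measured step that bears on this is the one from compound 1 to compound 3, a methyl on another aromatic carbon of the same ring, which moved the number by a 1.2-fold higher number from compound 1 to compound 3 (0.07 log units; within the scatter), within the scatter. On that basis the step to compound 4 is expected to stay within the scatter as well, with no clear direction. Compound 4 is therefore estimated at 5000 nM, within a range of 2500 nM to 10000 nM, corresponding to an expected step of a 1.2-fold lower number from compound 1 to compound 4 (0.08 log units; within the scatter).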

Compound 4, half-maximal inhibitory concentration: 1000 nM
The estimate for compound 4 lay 5.0-fold (0.70 log units) above the measured number; the whole stated range lies above it.
By their numbers in this assay, from the lowest: compound 4; then compound 2; then compounds 1 and 3 (each within the scatter of the next).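

In this assay, methyl in place of hydrogen next to the ring nitrogen gives a 6.0-fold lower number from compound 1 to compound 4 (0.78 log units; beyond the scatter), whereas a methyl on another aromatic carbon of the same ring gives a 1.2-fold higher number from compound 1 to compound 3 (0.07 log units; within the scatter). The same single added carbon therefore does not behave alike at these two places on the ring: in this pair of steps, the place of the methyl decides whether the number moves beyond the scatter. The information available offers no explanation for this difference between the two positions.

The compounds shown leave open whether the lower number next to the ring nitrogen is particular to methyl. An ethyl group, a methoxy group or an amine at that place could show whether other groups give a similar step or a different one.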